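Solubility notes: aryl swap on the shared core

The source may hold more compounds than are shown below. What is called first, only, known or untested is meant among the compounds shown, and "the series" means these compounds.

Compound 1 `CNC(=O)c1cc(Oc2ccc3nc(Nc4ccccc4Br)ncc3c2)ccn1` sits at a limit of a physicochemical assay for solubility, at pH 7; on this read-out higher numbers stand for higher solubility and lower numbers for lower solubility: compound 1 gives < 1000 nM. Compound 2 `CNC(=O)c1cc(Oc2ccc3nc(Nc4cccc(OC(F)(F)F)c4)ncc3c2)ccn1` also sits at a limit in this assay: compound 2 gives < 1000 nM. The step that the two limits leave unreadable from compound 1 to compound 2 cannot be sized, since both readings sit at the limit of < 1000 nM in this assay, at which 2 of the 2 values shown sit. Compound 3 `CNC(=O)c1cc(Oc2ccc3nc(Nc4ccc(F)cc4)ncc3c2)ccn1` carries 4-fluorophenyl in place of 3-(trifluoromethoxy)phenyl on a nitrogen on an aromatic ring. For the measured compounds named here, no measured step reads on this change, and the only measured step is unreadable, so no direction beyond the scatter is expected in this assay. Compound 3 is therefore expected near 800 nM, spanning 150 nM to 4000 nM, a step that the limit leaves unreadable from compound 2 to compound 3.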

Compound 3, solubility: < 1000 nM
Compound 3 was reported as a limit (the forecaster's own chance of this, stated with the estimate: 60%); the middle value lies beyond the limit too.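

No step among compound 1, compound 2 and compound 3 can be read in this assay, because all three sit at the same limit: the limit of < 1000 nM in this assay, at which 3 of the 3 values shown sit.

Going by these compounds, whether the 2-bromophenyl, 3-(trifluoromethoxy)phenyl and 4-fluorophenyl compounds differ at all in this assay stays open.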